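The source may hold more compounds than are shown below. What is called first, only, known or untested is meant among the compounds shown, and "the series" means these compounds.

Measured so far in an assay on HEK293 cells for inhibition of N-acylethanolamine-hydrolyzing acid amidase (Rattus norvegicus), read by LC-MS, with a stated time of 30 min; a higher number here means a weaker inhibitor, a lower number a stronger inhibitor:
- compound 1 `O=C(CCCCCc1cccc(O)c1)N1CCOC1=O`: 8640 nM
- compound 2 `COc1cccc(CCCCCC(=O)N2CCOC2=O)c1`: 16300 nM

Among the measured compounds shown here, compound 2 holds the higher of the two numbers; the only neighbour is compound 1, and the gap between them is a 1.9-fold higher number from compound 1 to compound 2 (0.28 log units; within the scatter), so the two cannot be told apart on these data.

Compound 3 `O=C(CCCCCc1cccc(C(F)(F)F)c1)N1CCOC1=O` is the next member. It differs from compound 2 by trifluoromethyl in place of methoxy on an aromatic carbon. For the measured compounds named here, no measured pair covers this exchange. Going by the values given here, the single measured step, a 1.9-fold higher number from compound 1 to compound 2 (0.28 log units; within the scatter), concerns the methyl in place of hydrogen on the ring oxygen and lies within the scatter; it says nothing about replacing the whole methoxy by trifluoromethyl. With no guide for direction or size, the working expectation for compound 3 is a step within the scatter, a 1.3-fold lower number from compound 2 to compound 3 (0.10 log units; within the scatter), with a wide range on either side. Compound 3 is thus estimated at 13000 nM in this assay, between 4000 nM and 45000 nM.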

Compound 3, half-maximal inhibitory concentration: 58 nM
Compound 3: middle estimate off by 220-fold (2.35 log units), on the high side; measured number outside the range, below it.
By their numbers in this assay, from the lowest: compound 3; then compounds 1 and 2 (each within the scatter of the next).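

In this assay, the group on this aromatic carbon, meta to a large group, proves to matter strongly: trifluoromethyl in place of methoxy gives a 280-fold lower number from compound 2 to compound 3 (2.45 log units; beyond the scatter) and trifluoromethyl in place of hydroxy gives a 150-fold lower number from compound 1 to compound 3 (2.17 log units; beyond the scatter), both large steps. The earlier hydroxy and methoxy pair could not be told apart, so only now does this position show that it can move the number far beyond the scatter, and it does so with a group that has no oxygen. Nothing shown here accounts for the size of this gain.

Going by these compounds, whether a chlorine, a nitrile or an amine on this carbon would match trifluoromethyl stays open. Also open, on these data alone, is whether the gain would hold with a longer chain in place of the present one.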